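A few compounds are considered here, and "the series" means these few. Any claim that something is new, unique, unknown or untested is made for them only; others in the source may bear on it.

Within the data shown here, compound 2 `CC1=CC[C@H]2[C@H](CC[C@]2(C)O)C(C)(C)[C@@H]1CC[C@H]1[C@]2(C)CC[C@H](OC(=O)c3ccc([N+](=O)[O-])cc3)C(C)(C)O[C@H]2CC[C@@]1(C)O` stands lowest of the two numbers measured so far in a functional assay on MDA-MB-231 cells (Homo sapiens) for antiproliferative activity, read by MTT assay, with a stated time of 72 h; a higher number here means a weaker inhibitor, a lower number a stronger inhibitor: compound 2 gives 8900 nM. Among the measured compounds shown here, compound 1 `CC1=CC[C@H]2[C@H](CC[C@]2(C)O)C(C)(C)[C@@H]1CC[C@H]1[C@]2(C)CC[C@H](OC(=O)NCc3ccccc3)C(C)(C)O[C@H]2CC[C@@]1(C)O` gives 40300 nM, and the one measured step, a 4.5-fold lower number from compound 1 to compound 2 (0.66 log units; beyond the scatter), was modest though beyond the scatter. Compound 3 `CC1=CC[C@H]2[C@H](CC[C@]2(C)O)C(C)(C)[C@@H]1CC[C@H]1[C@]2(C)CC[C@H](OC(=O)c3ccc(C(F)(F)F)c(F)c3)C(C)(C)O[C@H]2CC[C@@]1(C)O` carries a different kind of change: 3-fluoro-4-(trifluoromethyl)phenyl in place of 4-nitrophenyl on a carbonyl carbon. That measured step swapped an amine-linked group for an aromatic ring, whereas here one aromatic ring replaces another, so it offers only loose guidance. Compound 3 is therefore expected to stay near compound 2, with a 1.0-fold higher number from compound 2 to compound 3 (0.00 log units; within the scatter) within the scatter. The estimate for compound 3 is 9000 nM, with a range from 3000 nM to 27000 nM.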

Compound 3, half-maximal inhibitory concentration: 22200 nM
The estimate for compound 3 lay 2.5-fold (0.39 log units) below the measured number; low and high end bracket the measured number.
By their numbers in this assay, from the lowest: compound 2; then compounds 3 and 1 (each within the scatter of the next).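

At this carbonyl carbon, the identity of the aromatic ring's substituents matters: with a six-membered aromatic ring kept in place, a 2.5-fold higher number from compound 2 to compound 3 (0.40 log units; beyond the scatter) shows a modest change. Replacing benzylamino with 3-fluoro-4-(trifluoromethyl)phenyl gives a 1.8-fold lower number from compound 1 to compound 3 (0.26 log units; within the scatter), so compound 1 and compound 3 cannot be told apart. Nothing available accounts for these results. Going by these compounds, it remains open where a plain phenyl ring would fall relative to compound 2 and compound 3. A ring carrying only fluorine or only trifluoromethyl would be needed to separate the contributions of those two groups.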